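A few compounds are considered here, and "the series" means these few. Any claim that something is new, unique, unknown or untested is made for them only; others in the source may bear on it.

Measured compounds in a physicochemical assay for lipophilicity, using the shake flask method, in phosphate buffer, measured as octanol-water partition, at pH 7.4; on this read-out lower numbers stand for lower lipophilicity and higher numbers for higher lipophilicity: compound 1 `COc1cc(-c2cc(C(=O)O)c3ccccc3n2)ccc1OCC(=O)Nc1cccc(C)c1` gives 1.5; compound 2 `COc1cc(-c2cc(C(=O)O)c3ccccc3n2)ccc1OCC(=O)Nc1cccc(F)c1` gives 1.6; compound 3 `COc1cc(-c2cc(C(=O)O)c3ccccc3n2)ccc1OCC(=O)Nc1ccc(C(F)(F)F)cc1` gives 1.6.

Compound 3 stands level with compound 2, and a number 0.10 log units higher from compound 1 to compound 3 (within the scatter) stays within the scatter, so the three numbers cannot be told apart. Compound 4 `COc1cc(-c2cc(C(=O)O)c3ccccc3n2)ccc1OCC(=O)NCc1cccs1` differs from compound 3 by (thiophen-2-yl)methyl in place of 4-(trifluoromethyl)phenyl on an amide-type nitrogen. Within the data shown here, no measured step swaps an aryl group for an arylmethyl group on this nitrogen; the nearest steps, a number 0.10 log units higher from compound 1 to compound 3 (within the scatter) and no change at the digits printed from compound 2 to compound 3 (within the scatter), only vary the aryl group and both stayed within the scatter. The change to compound 4 is of a different kind, and a modest downward step in this assay is expected. Compound 4 is estimated at 1.1, between 0.7 and 1.5, which means a step of a number 0.50 log units lower from compound 3 to compound 4 (beyond the scatter).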

Compound 4, distribution coefficient: 0
Compound 4: middle estimate off by 1.10 log units, on the high side; the whole stated range lies above it.
By their numbers in this assay, from the lowest: compound 4; then compounds 1, 2 and 3 (each within the scatter of the next).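

On the amide-type nitrogen, where the aryl groups of compounds 1, 2 and 3 could not be told apart in this assay, (thiophen-2-yl)methyl brought a large fall. It appears against 4-(trifluoromethyl)phenyl (a number 1.60 log units lower from compound 3 to compound 4 (beyond the scatter)), 3-fluorophenyl (a number 1.60 log units lower from compound 2 to compound 4 (beyond the scatter)) and 3-methylphenyl (a number 1.50 log units lower from compound 1 to compound 4 (beyond the scatter)), so this position can move the read-out strongly. No evidence is available that accounts for the fall.

Compound 4 changes the ring and its attachment together, so the compounds shown do not separate the two. As far as these compounds go, whether a benzyl group on this nitrogen would give a similar number remains open, as does the effect of a thiophen-2-yl group attached directly.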